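Trimming one ethyl to methyl in compound 2

The source may hold more compounds than are shown below. What is called first, only, known or untested is meant among the compounds shown, and "the series" means these compounds.

In a functional assay on P388 cells (Mus musculus) for cytotoxicity (on this read-out lower numbers stand for stronger inhibition and higher numbers for weaker inhibition), compound 1 (`CC/C=C/C(CC)CCCC1(CC)C[C@H](CC)[C@H](CC(=O)O)OO1`) gives 0.5 ug/mL as its half-maximal inhibitory concentration, while compound 2 (`CC/C=C/C(CC)C/C(=C/C(O)(CC)CC(O)(/C=C/C(=O)O)CC)CC`) gives 10 ug/mL on the same read-out. Compound 2 therefore holds the higher of the two numbers, meaning the weaker result, and the gap lies beyond the usual scatter. Compound 3 (`CC/C=C/C(CC)C/C(C)=C/C(O)(CC)CC(O)(/C=C/C(=O)O)CC`) differs from compound 2 in one place, as hydrogen in place of methyl on a saturated chain carbon bound to a double-bonded chain carbon shows, with hydrogen in place of methyl on a saturated chain carbon bound to a double-bonded chain carbon; cut one bond further out, this reads ethyl to methyl. In this assay, within the data shown here, no measured pair shows this change, so the closest guide is compound 2 at 10 ug/mL as a starting point. The expected change is no change at the digits printed from compound 2 to compound 3 (within the scatter) and so no step beyond the scatter in either direction. Compound 3 is expected at 10 ug/mL with an estimated range from 3 ug/mL to 30 ug/mL on this read-out.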

Compound 3, half-maximal inhibitory concentration: 10 ug/mL
Estimate against measurement, compound 3: no gap at the digits printed; the range from low to high includes it.
By their numbers in this assay, from the lowest: compound 1; then compounds 2 and 3 (each within the scatter of the next).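

In this assay, hydrogen in place of methyl on a saturated chain carbon bound to a double-bonded chain carbon gives no change at the digits printed from compound 2 to compound 3 (within the scatter), the only one-place comparison among the compounds shown. Among these compounds, it offers the first direct reading of this position: with ethyl cut to methyl, the two compounds read alike, so on this read-out the position accepts a chain shorter by one carbon. Nothing on hand explains this result.

On these data alone, whether a longer chain, such as propyl, or an amine at this place would also read alike remains open. Compound 1, at 0.5 ug/mL, differs from the others in more than one place, and no single change can be tied to its number.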